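The compounds below may be only part of what the source reports. "The series", "measured", "known", "first", "only" and "open" are said of these compounds alone.

Compound 1 `CNC(=O)c1cc(C(=O)NC2CC2)cc2c1OC[C@H]2c1cccc2[nH]ccc12` gives >= 142 ug/mL in a physicochemical assay for solubility (a lower number here means a less soluble compound, a higher number a more soluble compound), and this is a limit of the assay, not a number.
Compound 2 `CNC(=O)c1cc(C(=O)N[C@H]2[C@@H]3COC[C@@H]32)cc2c1OC[C@H]2c1cccc(OC)c1` gives >= 186 ug/mL in this assay, again a limit.
Compound 3 `CNC(=O)c1cc(C(=O)NC2CC2)cc2c1OC[C@H]2c1cccc(OC)c1` gives >= 161 ug/mL in this assay, also a limit.

Compound 3 therefore stands only at a limit, as do the other two compounds; none of the three values is a measured number, so compound 3 cannot be ranked among them. The unmeasured compound 4 `CNC(=O)c1cc(C(=O)NC2CC2)cc2c1OC[C@H]2c1cccc(F)c1` differs from compound 3 in one place: fluoro in place of methoxy on an aromatic carbon. Within the data shown here, two measured steps touch compound 3. The step that the two limits leave unreadable from compound 1 to compound 3 and the step that the two limits leave unreadable from compound 2 to compound 3 both run between limits, so neither gives a readable size or direction, and neither concerns the methoxy position changed here. With only limits at the limit of >= 142 ug/mL in this assay, at which 1 of the 3 values shown sits, the limit of >= 161 ug/mL in this assay, at which 1 of the 3 values shown sits, and the limit of >= 186 ug/mL in this assay, at which 1 of the 3 values shown sits, to go on, no step beyond the scatter can be read or expected in this assay, and the most likely outcome is that compound 4 also reports a limit. Compound 4 is thus estimated at 150 ug/mL, within 50 ug/mL to 300 ug/mL, which means an expected step of an at least 1.0-fold lower number from compound 3 to compound 4 (0.03 log units; that floor lies within the scatter).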

Compound 4, solubility: >= 175 ug/mL
Compound 4: only a limit was reported; the forecaster's own chance of this, stated with the estimate: 65%; middle value at least 1.1-fold (0.06 log units) away from the limit.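

In this assay, among these compounds, compound 4 reports only a limit, as do compound 1 and compound 3, so neither the step from compound 3 to compound 4 nor the one from compound 1 to compound 4 can be read. The compounds shown leave open whether fluoro in place of methoxy shifts the read-out in this assay at all.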